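The source may report more compounds than this note shows. Statements on the series, on what has been measured and on what is new or still open speak of the compounds shown alone.

Measured so far:
- compound 1 `Cc1ccc(C2=NN(C3=NC(c4ccccc4)CS3)C(c3ccc4ccccc4c3)C2)cc1`: 290000 nM
- compound 2 `Cc1ccc(C2=NN(C3=NC(c4ccccc4)CS3)C(c3cccc4ccccc34)C2)cc1C`: 342000 nM

Both numbers come from an ADME assay on cells (Macrophage, Homo sapiens) for antiproliferative activity, read by CCK-8 assay, with a stated time of 24 h; on this read-out higher numbers stand for lower toxicity in this test and lower numbers for higher toxicity in this test. Among the measured compounds shown here, compound 1 gives 290000 nM in this assay and compound 2 gives 342000 nM; the two figures sit within the scatter of each other, so compound 1 is not separated from compound 2 on what has been measured, and no step between them has been worked out. The pair shares the same core and differs in the naphthyl group and in the methyl pattern on the phenyl ring, so nothing can be read from it about either change alone.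

Compound 3 `Cc1ccc(C2=NN(C3=NC(c4ccccc4)CS3)C(c3ccc4ccccc4c3)C2)cc1C` is not yet measured. It differs from compound 1 by methyl in place of hydrogen on an aromatic carbon. Compound 2 carries the same 3,4-dimethylphenyl group on the other naphthyl isomer and its number lies with that of compound 1, which is the only hint available. On that basis no shift beyond the scatter is expected in this assay, and the step is estimated at a 1.1-fold higher number from compound 1 to compound 3 (0.04 log units; within the scatter). Compound 3 is expected at about 320000 nM, within a range of 150000 nM to 650000 nM.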

Compound 3, half-maximal cytotoxic concentration: 382000 nM
Beside the measured number, compound 3's estimate is 1.2-fold (0.08 log units) below it; measured number inside the range.
By their numbers in this assay, from the lowest: compounds 1, 2 and 3 (each within the scatter of the next).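

Reading this position alone, the change from 4-methylphenyl to 3,4-dimethylphenyl gives a 1.3-fold higher number from compound 1 to compound 3 (0.12 log units; within the scatter) in this assay, so a methyl in place of hydrogen on this aromatic carbon, ortho to a methyl group and meta to a large group, is not separated from the hydrogen of compound 1. The naphthyl change, mixed with the methyl pattern in the earlier pair, can now also be read alone: naphthalen-2-yl in place of naphthalen-1-yl on a saturated ring carbon gives a 1.1-fold higher number from compound 2 to compound 3 (0.05 log units; within the scatter) in this assay, so neither single change moves the read-out beyond the scatter in these compounds. Nothing is available that bears on the meaning of either step.

Going by these compounds, whether a larger or differently built group on this aromatic carbon, such as methoxy, an amine or a carboxylic acid, would give a step beyond the scatter remains open. Also open, on these data alone, is whether replacing either naphthyl group with a plain phenyl or a chlorophenyl would separate a compound from compound 1 in this assay on the shared core.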